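Compound 4: Bromo for Chloro on the Ethenyl-Linked Phenyl

The source may hold more compounds than are shown below. What is called first, only, known or untested is meant among the compounds shown, and "the series" means these compounds.

Compound 1 `NS(=O)(=O)c1cc(-c2nnc(CNS(=O)(=O)c3ccc(Cl)cc3)o2)c(Cl)cc1SCc1ccccc1`: 32000 nM
Compound 2 `NS(=O)(=O)c1cc(-c2nnc(/C=C/c3cccc(Cl)c3)o2)c(Cl)cc1SCc1ccccc1`: 12000 nM
Compound 3 `NS(=O)(=O)c1cc(-c2nnc(/C=C/c3ccc(Cl)cc3)o2)c(Cl)cc1SCc1ccccc1`: 12000 nM

All three were tested in a functional assay on HCT-116 cells (Homo sapiens) for cytotoxicity, read by MTT assay, with a stated time of 72 h; on this read-out lower numbers stand for stronger inhibition and higher numbers for weaker inhibition. Compound 3 stands level with compound 2 at the digits shown, and together they give the lowest numbers of the three; compound 1 sits furthest off, the step being a 2.7-fold lower number from compound 1 to compound 3 (0.43 log units; beyond the scatter). Compound 4 `NS(=O)(=O)c1cc(-c2nnc(/C=C/c3ccc(Br)cc3)o2)c(Cl)cc1SCc1ccccc1` differs from compound 3 by bromo in place of chloro on an aromatic carbon. The step that bears most closely on this change is no change at the digits printed from compound 2 to compound 3 (within the scatter), which also concerns the chloro on that same ring; a 2.7-fold lower number from compound 1 to compound 2 (0.43 log units; beyond the scatter) concerns a different part of the molecule. From that, the step from compound 3 to compound 4 is expected to be no change at the digits printed from compound 3 to compound 4 (within the scatter), nothing beyond the scatter. Compound 4 is therefore estimated at 12000 nM, within 6000 nM to 25000 nM.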

Compound 4, half-maximal inhibitory concentration: 15000 nM
The estimate for compound 4 lay 1.3-fold (0.10 log units) below the measured number; the measured number falls inside the stated range.
By their numbers in this assay, from the lowest: compounds 2, 3 and 4 (each within the scatter of the next); then compound 1.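

Bromo in place of chloro on the aromatic carbon para to a large group gives a 1.3-fold higher number from compound 3 to compound 4 (0.10 log units; within the scatter), so in this assay either halogen can stand at this position without a shift beyond the scatter. The 4-bromophenyl compares in the same way with the 3-chlorophenyl, at a 1.3-fold higher number from compound 2 to compound 4 (0.10 log units; within the scatter), while the gap to the sulfonylamino side chain remains, at a 2.1-fold lower number from compound 1 to compound 4 (0.33 log units; beyond the scatter). No measurement shown accounts for these results. On these data alone, whether an amine or a carboxylic acid at this position would shift the number beyond the scatter remains open.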